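Swapping Fluoro for Ethoxy on Compound 3

The source may report more compounds than this note shows. Statements on the series, on what has been measured and on what is new or still open speak of the compounds shown alone.

Measured compounds:
- compound 1 `COc1cc2c(=O)c(-c3csc4ccccc34)coc2c(OC)c1OC` gives > 10000 nM (a limit, not a number)
- compound 2 `COc1c(OC(C)C)cc2ccc(-c3cc(=O)c4ccccc4o3)cc2c1OC(C)C` gives > 10000 nM (a limit, not a number)
- compound 3 `O=C(/C=C/c1csc2ccccc12)c1cc(F)ccc1O` gives 7100 nM (a number)

The test used here is a functional assay on A549 cells (Homo sapiens) for antiproliferative activity, read by sulforhodamine B assay, with a stated time of 72 h (a lower number here means a stronger inhibitor, a higher number a weaker inhibitor), and it gives a real number for only one of these compounds. Among the measured compounds shown here, compound 3 stands at 7100 nM as the single measured number in the set. Compound 1 and compound 2 each report only the limit of > 10000 nM in this assay, at which 2 of the 3 values shown sit, and neither result is a number, so neither can be placed exactly against compound 3.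

The next compound to be tested is compound 4 `CCOc1ccc(O)c(C(=O)/C=C/c2csc3ccccc23)c1` which has not yet been measured. Compared with compound 3, it has ethoxy in place of fluoro on an aromatic carbon, meta to a large group and para to a hydroxy group ethoxy in place of fluoro on an aromatic carbon and the rest of the structure stays the same.

For the measured compounds named here, no measured pair here differs in only one place, so the set offers no guide to the size or direction of this change. The expected result is therefore no shift beyond the scatter, stated as a 1.2-fold lower number from compound 3 to compound 4 (0.07 log units; within the scatter) in this estimate. Compound 4 is estimated at 6000 nM in this assay with an expected range from 2000 nM to 15000 nM for a single measurement.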

Compound 4, half-maximal inhibitory concentration: 5400 nM
The estimate for compound 4 lay 1.1-fold (0.05 log units) above the measured number; the range from low to high includes it.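

Among the compounds shown here, the swap of fluoro for ethoxy is the first step in this set between two measured compounds that differ in one place, and in this assay it gives a 1.3-fold lower number from compound 3 to compound 4 (0.12 log units; within the scatter). Earlier compounds could say nothing about this position, but this step shows that, on an aromatic carbon meta to a large group and para to a hydroxy group, fluoro can give way to the larger ethoxy, which counts as a hydrogen-bond acceptor where fluoro does not, with no shift in the read-out beyond the usual scatter. Nothing measured here bears on why the two numbers stay so close to each other.

For the compounds shown here, a single step describes only one swap, so it remains open whether a longer chain such as butoxy, an amine or a carboxylic acid at this position would move the number beyond the scatter. Going by these compounds, the hydroxy group is the same in compound 3 and compound 4, so what it contributes to the activity of either compound also remains open.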